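The source may report more compounds than this note shows. Statements on the series, on what has been measured and on what is new or still open speak of the compounds shown alone.

Of the compounds shown here, three have so far been measured in an ADME assay on microsomes from liver (Rattus norvegicus) for metabolic stability, read by LC-MS, with a stated time of 45 min, tested at 2 uM; a lower number here means that less of the compound is left, a higher number that more of the compound is left. Compound 1, `Cc1cc(OCc2ccc(F)cc2F)c(Br)c(=O)n1Cc1ccc(CN(C)C)cc1`, gives 53% in this assay. Compound 2, `O=c1c(Br)c(OCc2ccc(F)cc2F)ccn1Cc1cccc(F)c1`, gives 16%, and compound 3, `Cc1cnc(-n2c(C)cc(OCc3ccc(F)cc3F)c(Br)c2=O)cn1`, gives 95%. Compound 1 therefore stands second highest of the three: its number lies beyond the scatter above that of compound 2, its nearest neighbour, and beyond the scatter below that of compound 3, the furthest from it. No two of these compounds differ in one place only, so none of the gaps between them can be read as the effect of a single change.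

The unmeasured compound 4, `Cc1cc(OCc2ccc(F)cc2F)c(Br)c(=O)n1Cc1ccc(CNC(=O)CO)cc1`, differs from compound 1 in exactly one place: ((hydroxymethyl)carbonyl)amino in place of dimethylamino on a saturated chain carbon bound to an aromatic carbon. The ((hydroxymethyl)carbonyl)amino group thus takes the place of the dimethylamino group on the saturated chain carbon bound to an aromatic carbon, with no net charge gained or lost. Among the compounds with values here, no measured pair shows this change, so its effect in this assay is untested. The expected step is a number 17 percentage points higher from compound 1 to compound 4 (beyond the scatter), a modest rise that goes beyond the scatter. The estimate for compound 4 in this assay is 70%, with a range from 50% to 90%.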

Compound 4, percent of the compound remaining: 82%
Compound 4: middle estimate off by 12 percentage points, on the low side; the measured number falls inside the stated range.
By their numbers in this assay, from the lowest: compound 2; then compound 1; then compound 4; then compound 3.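

In this assay, within the data shown here, putting ((hydroxymethyl)carbonyl)amino in place of dimethylamino on the saturated chain carbon bound to an aromatic carbon gives a number 29 percentage points higher from compound 1 to compound 4 (beyond the scatter), the first step in this set that can be read as the effect of a single change. It shows that this position is not indifferent to what it carries: with the rest of compound 1 left as it is, the exchange of this one group moves the number beyond the scatter, and it does so with no net charge on either group. No measurement that could say why the number rises accompanies this step.

From the compounds shown here alone, what remains open is which part of the entering group goes with the rise, the hydroxymethyl end or the carbonyl and amino part; a plain acetylamino group, a primary amine or a carboxylic acid on the same chain carbon would each bear on that question. A single pair also leaves open whether the same exchange would give a step of like size on a different core.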